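Piperazine cap swap on the nitroimidazole dithiocarbamate series

This account rests on a few compounds, and the source may have more. Where it says the series, first, only, none or still open, it means among the compounds named here.

Compound 1 `CCOC(=O)N1CCN(C(=S)SCC(O)Cn2c([N+](=O)[O-])cnc2C)CC1` and compound 2 `CCOC(=O)N1CCN(CC(O)Cn2c([N+](=O)[O-])cnc2C)CC1` carry the ethoxycarbonyl cap; compound 3 `CCN1CCN(C(=S)SCC(O)Cn2cc([N+](=O)[O-])nc2C)CC1` carries an ethyl cap on the same ring nitrogen. In a toxicity assay on HeLa cells (Homo sapiens) for cytotoxicity, read by MTT assay, with a stated time of 24 h (a higher number here means a weaker inhibitor, a lower number a stronger inhibitor), compound 1 gives 1610000 nM and compound 2 gives 3670000 nM. Compound 3 reaches only > 5000000 nM, which is a limit of the assay and not a number (the limit of > 5000000 nM in this assay, at which 1 of the 3 values shown sits). Compound 4 `CCOC(=O)N1CCN(C(=S)SCC(O)Cn2cc([N+](=O)[O-])nc2C)CC1` is not yet measured; it differs from compound 3 by ethoxycarbonyl in place of ethyl on an amine nitrogen in a ring. With compound 3 resting at a limit, the step from compound 3 to compound 4 is expected to be small, an at least 1.2-fold lower number from compound 3 to compound 4 (0.09 log units; that floor lies within the scatter), with no clear direction beyond the scatter. Compound 4 is estimated at 4000000 nM, within 1500000 nM to 9000000 nM, and a limit read-out remains possible.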

Compound 4, half-maximal inhibitory concentration: 2360000 nM
Beside the measured number, compound 4's estimate is 1.7-fold (0.23 log units) above it, and the stated range covers the measured number.
By their numbers in this assay, from the lowest: compounds 1, 4 and 2 (each within the scatter of the next, the first and the last beyond it). At a limit, above all of these: compound 3.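

Ethoxycarbonyl in place of ethyl on an amine nitrogen in a ring is the first change at this position that can be sized in this assay: an at least 2.1-fold lower number from compound 3 to compound 4 (0.32 log units; beyond the scatter). Compound 3 stays a limit of the assay and not a number: the limit of > 5000000 nM in this assay, at which 1 of the 4 values shown sits. With the ethoxycarbonyl cap held, 2-methyl-4-nitro-1H-imidazol-1-yl in place of 2-methyl-5-nitro-1H-imidazol-1-yl gives a 1.5-fold higher number from compound 1 to compound 4 (0.17 log units; within the scatter), so this exchange does not separate the two compounds.

Going by these compounds, the true size of the cap step stays open while one end of it is a limit. Also open, on these data alone, is how a longer alkyl chain or a carboxylic acid on that ring nitrogen would read.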